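Swapping a 3-methylphenyl for a naphthalen-1-yl group

This account rests on a few compounds, and the source may have more. Where it says the series, first, only, none or still open, it means among the compounds named here.

Measured compounds:
- compound 1, `CC(=O)c1ccc(-c2cn3ccnc3c(-c3ccc4ncn(C5CCCCC5)c4c3)n2)cc1`, 15.9%
- compound 2, `c1csc(-c2cn3ccnc3c(-c3ccc4ncn(C5CCCCC5)c4c3)n2)c1`, 21.1%
- compound 3, `Cc1cccc(-c2cn3ccnc3c(-c3ccc4ncn(Cc5ccccc5)c4c3)n2)c1`, 36.7%

These three compounds were tested in a functional assay on HCT-116 cells (Homo sapiens) for inhibition, read by sulforhodamine B assay, with a stated time of 48 h, tested at 10 uM; a higher number here means more inhibition at the concentration tested (going by the name of the read-out), a lower number less inhibition. Compound 3 gives the highest of the three numbers, 36.7%; compound 2 lies beyond the scatter below it, and compound 1 further still. Compound 4, `c1ccc(Cn2cnc3ccc(-c4nc(-c5cccc6ccccc56)cn5ccnc45)cc32)cc1`, has not yet been measured. It differs from compound 3 in one place: naphthalen-1-yl in place of 3-methylphenyl on an aromatic carbon.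

Within the data shown here, only one measured step involves an exchange of one aromatic group for another on an aromatic carbon, and that is a number 5.2 percentage points higher from compound 1 to compound 2 (within the scatter), a change that stayed within the scatter. Among the measured compounds shown here, no measured step covers a methylphenyl against a naphthyl group, so the guidance is thin. For the measured compounds named here, with the one comparable exchange showing no real movement, the expectation for compound 4 is a step of a number 1.7 percentage points lower from compound 3 to compound 4 (within the scatter), that is, nothing beyond the scatter in either direction. Compound 4 is therefore expected to give about 35% in this assay, with a plausible range from 15% to 55%.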

Compound 4, a percentage reported as inhibition, at one concentration (the size of the read-out at that concentration, not a potency): 32.9%
Compound 4: middle estimate off by 2.1 percentage points, on the high side; the range from low to high includes it.
By their numbers in this assay, from the lowest: compounds 1 and 2 (each within the scatter of the next); then compounds 4 and 3 (each within the scatter of the next).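

In this assay the step is a number 3.8 percentage points lower from compound 3 to compound 4 (within the scatter), so at this position, next to the ring nitrogen, a second fused aromatic ring (10 heavy atoms in naphthalen-1-yl against 7 in 3-methylphenyl) brings no change that can be told from the scatter. The earlier exchange at this position, a number 5.2 percentage points higher from compound 1 to compound 2 (within the scatter), was between two quite different aromatic groups on compounds carrying cyclohexyl, and this new step extends the same picture to a pair carrying benzyl, with a bulkier carbon-only group entering. Nothing shown here offers a measured reason why this exchange leaves the number where it is.

Going by these compounds, whether a group of another kind at this position, such as an amine or a carboxylic acid, would move the number beyond the scatter remains open. Also open are how cyclohexyl and benzyl compare with the same aromatic group in this place, as no pair shown differs only there, and how these compounds rank in potency, as a single concentration gives only the size of the read-out.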